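Furan to hydroxyphenyl: a chalcone step in macrophage cytotoxicity

The source may report more compounds than this note shows. Statements on the series, on what has been measured and on what is new or still open speak of the compounds shown alone.

Measured so far:
Compound 1, `C=CCOc1cc(/C=C/C(=O)c2c(O)cc(O)cc2OC)cc(OCC=C)c1Br`, gives 11500 nM.
Compound 2, `COCc1cc(O)c(C(=O)/C=C/c2cc(OC)c(OC)c(OC)c2)c(OC)c1`, gives 133000 nM.
Compound 3, `COc1cc(O)cc(O)c1C(=O)/C=C/c1ccco1`, gives 384000 nM.

All three compounds were tested in a toxicity assay on cells (Macrophage, Mus musculus, strain BALB/c) for cytotoxicity, read by MTT assay; on this read-out higher numbers stand for weaker inhibition and lower numbers for stronger inhibition. On these numbers compound 3 stands highest of the three, meaning it is the weakest inhibitor of cell viability shown here. Its nearest neighbour is compound 2, whose number is lower by a margin beyond the scatter; compound 1 is furthest away, with a much lower number.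

Compound 4, `COc1cc(O)cc(O)c1C(=O)/C=C/c1ccc(O)cc1`, is not yet measured. It shares the core of compound 3 and differs in one place: 4-hydroxyphenyl in place of furan-2-yl on a double-bonded chain carbon bound to a double-bonded chain carbon.

For the measured compounds named here, no step between two measured compounds isolates this kind of change, so the expectation rests only on the spread of the three values. The replacement keeps one hydrogen-bond acceptor and adds one hydrogen-bond donor on a larger aromatic ring. The values for compound 2 and compound 3 show that two different aromatic groups at this end of the chain give numbers that differ beyond the scatter, so a shift in compound 4 is plausible. A modest move toward lower numbers is expected. The step is expected to be a 2.6-fold lower number from compound 3 to compound 4 (0.41 log units; beyond the scatter). A change within the scatter cannot be excluded.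

Compound 4 is therefore expected to give about 150000 nM in this assay, with a likely range from 40000 nM to 500000 nM.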

Compound 4, half-maximal inhibitory concentration: 21700 nM
Compound 4: the middle estimate sits 6.9-fold (0.84 log units) above what was measured; the whole stated range lies above it.
By their numbers in this assay, from the lowest: compounds 1 and 4 (each within the scatter of the next); then compound 2; then compound 3.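

In this assay, placing 4-hydroxyphenyl in place of furan-2-yl on a double-bonded chain carbon bound to a double-bonded chain carbon gives an 18-fold lower number from compound 3 to compound 4 (1.25 log units; beyond the scatter) and counts as a large step. For the compounds shown here, compounds 3 and 4 share the rest of their structure, so this is the first reading that ties a change in the number to this one place, and it shows that the number is highly sensitive to the group found there. No measurement shown gives a reason for the size of this step.

The change swaps a five-membered ring containing oxygen for a six-membered carbon ring and adds a hydroxyl group all at once, so these compounds cannot show which of those differences carries the step; a plain phenyl ring at the same place would separate the ring from the hydroxyl group. Also open, on these data alone, is whether a methoxy group or an amine in place of that hydroxyl group would keep the number low, and whether the same swap would give a step of similar size on another core.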